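Swapping the aryl substituent pattern on the hydroxamic acid series

The compounds below may be only part of what the source reports. "The series", "measured", "known", "first", "only" and "open" are said of these compounds alone.

Compound 1 `O=C(CCC1=CCN(CCCc2ccc(Br)cc2)C1=O)NO` and compound 2 `CC(C)(C)c1ccc(CCCN2CC=C(CCC(=O)NO)C2=O)cc1` share a core that differs only at the aromatic ring. In a functional assay on PC-3 cells (Homo sapiens) for inhibition, read by sulforhodamine B assay (on this read-out higher numbers stand for weaker inhibition of growth and lower numbers for stronger inhibition of growth), compound 1 gives 3480 nM, and compound 2 gives 3480 nM, so compound 1 stands level with compound 2. Among the measured compounds shown here, the one step seen, no change at the digits printed from compound 1 to compound 2 (within the scatter), shows that exchanging a group on that ring left the read-out unchanged. Compound 3 `Cc1ccccc1CCCN1CC=C(CCC(=O)NO)C1=O` differs from compound 1 by 2-methylphenyl in place of 4-bromophenyl on a saturated chain carbon, three bonds along the chain from an amide-type nitrogen in a ring. For the measured compounds named here, since the only relevant step was flat, no change beyond the scatter is expected, a 1.0-fold higher number from compound 1 to compound 3 (0.00 log units; within the scatter). Compound 3 is therefore estimated at 3500 nM, within 1400 nM to 9000 nM.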

Compound 3, concentration for 50% growth inhibition: 3480 nM
Compound 3: middle estimate off by 1.0-fold (0.00 log units), on the high side, within the range that was stated.
By their numbers in this assay, from the lowest: compounds 1, 2 and 3 (each within the scatter of the next).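

Replacing 4-bromophenyl with 2-methylphenyl gave no change at the digits printed from compound 1 to compound 3 (within the scatter) in this assay. Where the earlier step exchanged only tert-butyl for bromo, this one also changes the ring numbering of the substituent, and the read-out stayed flat, so the number held across both kinds of change on this aryl group. From the compounds shown here alone, what stays open is whether an amine or a carboxylic acid on the aromatic ring would leave the read-out equally flat. Going by these compounds, a longer chain between the aromatic ring and the amide-type nitrogen is equally open. Nothing measured here accounts for the flat steps.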